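Benzylidene thiazolidinedione series: ring methoxy and amide nitrogen substitution

The source may report more compounds than this note shows. Statements on the series, on what has been measured and on what is new or still open speak of the compounds shown alone.

Measured compounds:
- compound 1, `COc1ccc(-c2nc3cc(/C=C4\SC(=O)NC4=O)ccc3[nH]2)cc1OC`, 570 nM
- compound 2, `COc1cc(OC)c(-c2nc3cc(/C=C4\SC(=O)NC4=O)ccc3[nH]2)cc1OC`, 1840 nM
- compound 3, `COc1ccc(-c2nc3cc(/C=C4\SC(=O)N(CC(=O)N5CCOCC5)C4=O)ccc3[nH]2)cc1OC`, 8930 nM

All three were run in a functional assay on A549 cells (Homo sapiens) for inhibition, read by MTT assay, with a stated time of 48 h; a lower number here means a stronger inhibitor, a higher number a weaker inhibitor. Compound 1 gives 570 nM and is the lowest number of the three. Compound 2 differs from compound 1 by methoxy in place of hydrogen on an aromatic carbon; in this assay compound 2 gives 1840 nM, and the step is a 3.2-fold higher number from compound 1 to compound 2 (0.51 log units; beyond the scatter). Compound 3 differs from compound 1 by ((morpholin-4-yl)carbonyl)methyl in place of hydrogen on an amide-type nitrogen in a ring; compound 3 gives 8930 nM, the highest of the three, and the step is a 16-fold higher number from compound 1 to compound 3 (1.19 log units; beyond the scatter).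

Compound 4, `COc1cc(OC)c(-c2nc3cc(/C=C4\SC(=O)N(CC(=O)N5CCOCC5)C4=O)ccc3[nH]2)cc1OC`, has not been measured. It differs from compound 3 by methoxy in place of hydrogen on an aromatic carbon. This is the same change as that from compound 1 to compound 2, made on the core of compound 3 instead of the core of compound 1; the two cores differ by the change described above for compound 1 to compound 3.

For the measured compounds named here, for compound 4 in this assay the step from compound 3 is expected to be about the same size as a 3.2-fold higher number from compound 1 to compound 2 (0.51 log units; beyond the scatter), that is a 2.7-fold higher number from compound 3 to compound 4 (0.43 log units; beyond the scatter), because the single earlier instance of this change, a 3.2-fold higher number from compound 1 to compound 2 (0.51 log units; beyond the scatter), lies beyond the scatter and there is nothing in the data to suggest the second core responds differently. Going by the values given here, with only one instance this rests on a thin base, and the spread is kept wide. Compound 4 is expected to give about 24000 nM, between 9000 nM and 65000 nM.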

Compound 4, half-maximal inhibitory concentration: 660 nM
Compound 4: the middle estimate sits 36-fold (1.56 log units) above what was measured; the whole stated range lies above it.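

Notes on carrying the change across cores, in this assay: methoxy in place of hydrogen on an aromatic carbon, read as 3,4-dimethoxyphenyl to 2,4,5-trimethoxyphenyl, does not transfer between the two cores, and with the ((morpholin-4-yl)carbonyl)methyl group on the amide-type nitrogen it gives a 14-fold lower number from compound 3 to compound 4 (1.13 log units; beyond the scatter), reversing the direction seen without that group: the same change on two cores in this assay, a 3.2-fold higher number (0.51 log units; beyond the scatter) from compound 1 to compound 2 and a 14-fold lower number (1.13 log units; beyond the scatter) from compound 3 to compound 4, 44-fold (1.64 log units) apart, beyond the scatter of two such steps. The nitrogen substitution reverses in the same way, and with the 2,4,5-trimethoxyphenyl group present it gives a 2.8-fold lower number from compound 2 to compound 4 (0.45 log units; beyond the scatter), set against the step on the 3,4-dimethoxyphenyl core: the same change on two cores in this assay, a 16-fold higher number (1.19 log units; beyond the scatter) from compound 1 to compound 3 and a 2.8-fold lower number (0.45 log units; beyond the scatter) from compound 2 to compound 4, 44-fold (1.64 log units) apart, beyond the scatter of two such steps. These four compounds therefore show that, in this assay, the effect of each change depends on the other, so neither step can be carried from one of these cores to the other at face value; they do not show why the direction reverses or whether it would reverse on any other core.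

From the compounds shown here alone, it remains open whether the reversal is specific to the ((morpholin-4-yl)carbonyl)methyl group or also appears with a piperazine amide, a carboxylic acid or a longer chain on the same nitrogen. Also open, going by these compounds, is whether a hydroxy group or a fluorine in place of the entering methoxy would behave in the same way.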